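This account rests on a few compounds, and the source may have more. Where it says the series, first, only, none or still open, it means among the compounds named here.

Compound 1, `O=C(N/N=C/c1cccc(Cl)c1)c1cccnc1Nc1cccc(C(F)(F)F)c1`: 77.8%
Compound 2, `O=C(N/N=C/c1ccc(Cl)cc1)c1cccnc1Nc1cccc(C(F)(F)F)c1`: 52.4%
Compound 3, `O=C(N/N=C/c1ccc(O)c(O)c1)c1cccnc1Nc1cccc(C(F)(F)F)c1`: 51.4%

All three were tested in a functional assay on the whole organism (strain Wistar) for inhibition, with Rattus norvegicus as the target, read by paw edema, with a stated time of 30 min, at a dose of 10 mg/kg by the intraperitoneal route; on this read-out higher numbers stand for more inhibition at the one dose given (going by the name of the read-out) and lower numbers for less inhibition. Compound 3 gives the lowest of the three numbers there, yet compound 2 sits within the scatter of it (a number 1 percentage points lower from compound 2 to compound 3 (within the scatter)), and only compound 1 stands clearly apart (a number 26.4 percentage points lower from compound 1 to compound 3 (beyond the scatter)). Compound 4, `O=C(N/N=C/c1ccncc1)c1cccnc1Nc1cccc(C(F)(F)F)c1`, has not yet been measured. It differs from compound 3 in one place: pyridin-4-yl in place of 3,4-dihydroxyphenyl on a carbon with a double bond to nitrogen. Within the data shown here, no measured step exchanges this group, so none bears directly on the change. The two steps leading away from compound 1 (a number 25.4 percentage points lower from compound 1 to compound 2 (beyond the scatter) and a number 26.4 percentage points lower from compound 1 to compound 3 (beyond the scatter)) show that a swap at this carbon can move the number by a modest amount, while the third step (a number 1 percentage points lower from compound 2 to compound 3 (within the scatter)), also a swap at the same carbon, stayed within the scatter. Compound 4 is therefore expected to give about 50%, in a range from 30% to 70%. The expected step of a number 1.4 percentage points lower from compound 3 to compound 4 (within the scatter) is estimated to stay within the scatter.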

Compound 4, a percentage reported as inhibition, in the whole organism at one dose (the size of the read-out at that dose, not a potency): 68.1%
The estimate for compound 4 lay 18.1 percentage points below the measured number, within the range that was stated.
By their numbers in this assay, from the lowest: compounds 3 and 2 (each within the scatter of the next); then compounds 4 and 1 (each within the scatter of the next).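

Pyridin-4-yl on the carbon with a double bond to nitrogen separates compound 4 from both earlier low compounds in this assay (a number 16.7 percentage points higher from compound 3 to compound 4 (beyond the scatter); a number 15.7 percentage points higher from compound 2 to compound 4 (beyond the scatter)). Among these compounds, until now, 3-chlorophenyl was the only group at this carbon that stood apart from the others, but the ring with a hetero atom now shares that place (a number 9.7 percentage points lower from compound 1 to compound 4 (within the scatter)). A group with no chlorine and with 0 hydrogen-bond donors can therefore stand level with compound 1 here, whereas 4-chlorophenyl and 3,4-dihydroxyphenyl do not. Nothing at hand accounts for these steps.

The compounds shown leave open whether the place of the ring nitrogen matters, as pyridin-3-yl or pyridin-2-yl would show. They also leave open how a phenyl ring carrying an amine or a carboxylic acid would fare at this carbon.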